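The source may report more compounds than this note shows. Statements on the series, on what has been measured and on what is new or still open speak of the compounds shown alone.

The measured compounds:
Compound 1, `Cc1cccc(Nc2ncnc3c2nnn3Cc2ccccc2)c1`, gives 1100 nM in an assay on cell membranes for binding affinity to adenosine receptor A1 (Bos taurus), read by radioligand binding; on this read-out higher numbers stand for weaker inhibition and lower numbers for stronger inhibition.
Compound 2, `Cc1cccc(Nc2ncnc3c2nnn3Cc2ccccc2Cl)c1`, gives 5880 nM in this assay.
Compound 3, `O=[N+]([O-])c1cccc(Nc2ncnc3c2nnn3Cc2ccccc2)c1`, gives 443 nM in this assay.

Compound 1 and compound 2 share a core and differ in one place only: chloro in place of hydrogen on an aromatic carbon
This single change gives a 5.3-fold higher number from compound 1 to compound 2 (0.73 log units; beyond the scatter), so compound 2 inhibits more weakly than compound 1. Compound 3 differs from compound 1 in another place, set out below, and here the step is a 2.5-fold lower number from compound 1 to compound 3 (0.39 log units; beyond the scatter). Compound 3 thus has the lowest number of the three measured, and its steps to compound 1 and to compound 2 both lie beyond the scatter.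

Compound 4, `O=[N+]([O-])c1cccc(Nc2ncnc3c2nnn3Cc2ccccc2Cl)c1`, has not yet been measured in this assay. It stands to compound 3 as compound 2 stands to compound 1: chloro in place of hydrogen on an aromatic carbon
The surroundings of the place are described in the same words in both cases, so this is the same change seen once already. The two cores differ as follows: nitro in place of methyl on an aromatic carbon
Compound 4 is expected to follow the earlier step, because the same change gave a 5.3-fold higher number from compound 1 to compound 2 (0.73 log units; beyond the scatter), and the expected step is a 5.2-fold higher number from compound 3 to compound 4 (0.72 log units; beyond the scatter). That rests on a single earlier example, so the range is kept wide. Compound 4 is expected to give about 2300 nM in this assay, with a likely span from 900 nM to 6000 nM.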

Compound 4, inhibition constant: 3300 nM
Beside the measured number, compound 4's estimate is 1.4-fold (0.16 log units) below it; the range from low to high includes it.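

In this assay, putting chloro in place of hydrogen, which turns benzyl into 2-chlorobenzyl, gives a 7.4-fold higher number from compound 3 to compound 4 (0.87 log units; beyond the scatter), and this agrees with the step seen on the core of compound 1: the same change on two cores in this assay, a 5.3-fold higher number (0.73 log units; beyond the scatter) from compound 1 to compound 2 and a 7.4-fold higher number (0.87 log units; beyond the scatter) from compound 3 to compound 4, 1.4-fold (0.14 log units) apart, within the scatter of two such steps The other change, nitro in place of methyl, gives a 1.8-fold lower number from compound 2 to compound 4 (0.25 log units; within the scatter); on its own this step cannot be told apart from repeat-measurement noise, but it does not disagree with the clearer step seen earlier: the same change on two cores in this assay, a 2.5-fold lower number (0.39 log units; beyond the scatter) from compound 1 to compound 3 and a 1.8-fold lower number (0.25 log units; within the scatter) from compound 2 to compound 4, 1.4-fold (0.14 log units) apart, within the scatter of two such steps Across these four compounds, then, each change looks much the same whichever form of the other place it is made on, so an estimate carried from one core to the other held up here, but two cores in one assay cannot show that this holds generally, and they do not explain why either change acts as it does.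

The compounds shown leave open whether the same carry-over would hold if fluoro or methoxy stood in place of the chloro, or if an amine or a carboxylic acid stood in place of the nitro. They also leave open how a longer chain in place of the benzyl group would behave, and whether the two changes would still act separately there.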